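A few compounds are considered here, and "the series" means these few. Any claim that something is new, unique, unknown or untested is made for them only; others in the source may bear on it.

For the measured compounds named here, in an assay on isolated protein for inhibition of long-chain fatty acid transport protein 1 (Mus musculus) (a higher number here means a weaker inhibitor, a lower number a stronger inhibitor), compound 2 `CCn1c(CNc2ccccc2)nnc1SCc1nc2cc(C(=O)C(C)C)ccc2o1` gives 520 nM, the lower of the two numbers known so far. Compound 1 `CCC(=O)c1ccc2oc(CS(=O)(=O)c3nnc(CNc4ccccc4)n3CC)nc2c1` gives 11900 nM in this assay, a far higher number, beyond the scatter. Compound 3 `CCn1c(CNc2ccccc2)nnc1SCc1nc2cc(OC(F)(F)F)ccc2o1` has not yet been measured. It differs from compound 2 by trifluoromethoxy in place of isopropylcarbonyl on an aromatic carbon. No measured pair among these compounds shows this kind of change. The step is expected to be a moderate loss, with the estimated step of a 2.9-fold higher number from compound 2 to compound 3 (0.46 log units; beyond the scatter) somewhat beyond the scatter. Compound 3 is therefore estimated at 1500 nM, with a range from 500 nM to 5000 nM.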

Compound 3, half-maximal inhibitory concentration: 91 nM
Beside the measured number, compound 3's estimate is 16-fold (1.22 log units) above it; the whole stated range lies above it.
By their numbers in this assay, from the lowest: compound 3; then compound 2; then compound 1.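

In (this assay), the aromatic carbon meta to a fused ring and para to a fused ring proves open to change: trifluoromethoxy in place of isopropylcarbonyl gives a stronger inhibitor (a 5.7-fold lower number from compound 2 to compound 3 (0.76 log units; beyond the scatter)). The two groups match in heavy atoms and hydrogen-bond acceptors, so these counts do not separate them. No measurement shown bears on why the number falls. As far as these compounds go, how a methoxy group, a chlorine atom or an amine would read at this position stays open. So does whether the trifluoromethoxy step would hold with a longer chain in place of the ethyl group.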